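Aryl swap on the hydrazone arm of the series

This account rests on a few compounds, and the source may have more. Where it says the series, first, only, none or still open, it means among the compounds named here.

Compound 1 `CN(C)CCn1cnnc1-c1cc(Oc2ccc(NC(=O)N/N=C/c3ccccc3O[N+](=O)[O-])cc2F)ccn1` gives 1020 nM in a functional assay on MKN-45 cells (Homo sapiens) for cytotoxicity, read by MTT assay, with a stated time of 72 h; on this read-out higher numbers stand for weaker inhibition and lower numbers for stronger inhibition. Compound 2 `CN(C)CCn1cnnc1-c1cc(Oc2ccc(NC(=O)N/N=C/c3ccc(F)cc3F)cc2F)ccn1` gives 810 nM in this assay; the step of a 1.3-fold lower number from compound 1 to compound 2 (0.10 log units; within the scatter) exchanged one aryl group for another on the carbon with a double bond to nitrogen. Going by the values given here, on the two numbers so far, compound 2 and compound 1 lie within the scatter of each other, so neither can be set apart from the other.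

Compound 3 `COc1cc(/C=N/NC(=O)Nc2ccc(Oc3ccnc(-c4nncn4CCN(C)C)c3)c(F)c2)ccc1O` carries the change (4-hydroxy-3-methoxyphenyl in place of 2,4-difluorophenyl on a carbon with a double bond to nitrogen). Among the compounds with values here, the only step that bears on this position is the one from compound 1 to compound 2, which stayed within the scatter although it also replaced the whole aryl group on that carbon. Within the data shown here, there is no measured step that shows the effect of a hydroxy or methoxy substituent here, so the expectation rests on that single comparison.

The step from compound 2 to compound 3 is therefore expected to be a 1.1-fold higher number from compound 2 to compound 3 (0.05 log units; within the scatter), with no shift beyond the scatter. Compound 3 is expected to give 900 nM in this assay, with a range from 350 nM to 2500 nM.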

Compound 3, half-maximal inhibitory concentration: 3780 nM
For compound 3 the middle estimate is 4.2-fold (0.62 log units) below the measured one, outside the stated range (above it).
By their numbers in this assay, from the lowest: compounds 2 and 1 (each within the scatter of the next); then compound 3.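

The aryl group on the carbon with a double bond to nitrogen does matter in this assay: the earlier exchange stayed within the scatter, but both new steps (a 4.7-fold higher number from compound 2 to compound 3 (0.67 log units; beyond the scatter) and a 3.7-fold higher number from compound 1 to compound 3 (0.57 log units; beyond the scatter)) lie beyond it and point the same way. Compound 1 and compound 2, which carry 2-(nitrooxy)phenyl and 2,4-difluorophenyl, stay within the scatter of each other, and the 4-hydroxy-3-methoxyphenyl group of compound 3 gives the highest number of the three, so on these compounds this position tolerates some aryl exchange but not every one. Relative to 2,4-difluorophenyl, the entering group has 1 hydrogen-bond donor and 2 hydrogen-bond acceptors where the leaving group has none and loses both fluorines, but no measurement here ties the higher number to any of these differences.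

The hydroxy and methoxy groups enter together, so the compounds shown do not tell which of them, or whether only the pair, goes with the step. Also open, on these data alone, is how this position responds to an amine or a carboxylic acid on the aryl ring, and whether a phenyl ring bearing a single hydroxy group would sit nearer compound 2 or compound 3.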